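Cytotoxicity notes: fluoro to chloro on the fused ring

A few compounds are considered here, and "the series" means these few. Any claim that something is new, unique, unknown or untested is made for them only; others in the source may bear on it.

The series is read in an ADME assay on HepG2 cells (Homo sapiens) for cytotoxicity, with a stated time of 72 h; on this read-out higher numbers stand for an effect only at larger amounts of compound and lower numbers for an effect already at smaller amounts. Compound 1 `COc1ccc(-c2nc3ccccc3s2)cc1NC(=O)c1cc([N+](=O)[O-])ccc1Cl` reaches only a limit of the assay rather than a number; in this assay compound 1 shows > 25000 nM. Compound 2 `O=C(Nc1nc2ccc(F)cc2s1)c1cc([N+](=O)[O-])ccc1Cl` likewise reaches only a limit; in this assay compound 2 shows > 27000 nM. Going by the values given here, no step between the two can be sized, since both values sit at a limit: the limit of > 25000 nM in this assay, at which 1 of the 2 values shown sits, and (the limit of > 27000 nM in this assay, at which 1 of the 2 values shown sits). Among the compounds with values here, compound 2 thus stands at the top of what the read-out reports, with no measured step to any other compound.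

Compound 3 `O=C(Nc1nc2ccc(Cl)cc2s1)c1cc([N+](=O)[O-])ccc1Cl` differs from compound 2 by chloro in place of fluoro on an aromatic carbon. Within the data shown here, with compound 2 at a limit and no measured step to lean on, no change beyond the scatter of this assay is expected. For compound 3 the value in this assay is estimated at 30000 nM, within 10000 nM to 100000 nM. The expected step is a step that the limit leaves unreadable from compound 2 to compound 3, and a further limit rather than a number is the likely outcome.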

Compound 3, half-maximal effective concentration: > 27000 nM
Compound 3 was reported as a limit (the forecaster's own chance of this, stated with the estimate: 85%); the middle value lies beyond the limit too.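

No step from compound 2 to compound 3 can be read in this assay, since both stand at the same limit: the limit of > 27000 nM in this assay, at which 2 of the 3 values shown sit.

The compounds shown leave open whether chloro in place of fluoro on an aromatic carbon changes cytotoxicity at all, and at what concentration compound 2 or compound 3 would show an effect.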